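A chloro-to-fluoro swap in a cell toxicity test

The source may hold more compounds than are shown below. What is called first, only, known or untested is meant among the compounds shown, and "the series" means these compounds.

Testing compounds on healthy cells shows how much they harm cells in general. In an ADME assay on L6 cells (Rattus norvegicus) for cytotoxicity, read by resazurin assay, with a stated time of 72 h (a lower number here means a stronger inhibitor, a higher number a weaker inhibitor), compound 1 `OC(c1ccc(Cl)cc1)(c1ccc(Cl)cc1)c1cncnc1` gives 47200 nM as its reading, and compound 2 `OC(c1ccc(Cl)cc1)(c1cccnc1)c1ccccc1Cl` gives 61300 nM as its reading. These two numbers lie within the usual scatter of each other, so the data do not separate them. Both sit in the same range, and that is where compound 2 stands so far.

Compound 3 `OC(c1ccc(Cl)cc1)(c1cccnc1)c1ccccc1F` has not yet been measured. It is compound 2 with a single change, (fluoro in place of chloro on an aromatic carbon), which is fluoro in place of chloro on an aromatic carbon, ortho to a large group. In other words, 2-chlorophenyl becomes 2-fluorophenyl.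

For the measured compounds named here, no measured pair of compounds shows what this swap does in this assay, so any forecast is uncertain. The expectation is a small move toward a higher number, one that stays within the scatter. The estimated step is a 1.1-fold higher number from compound 2 to compound 3 (0.06 log units; within the scatter) and no larger shift is expected. For compound 3 the expected value is 70000 nM, with 35000 nM to 130000 nM as the estimated range.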

Compound 3, half-maximal inhibitory concentration: > 100000 nM
Compound 3: a limit, no number; the forecaster's own chance of this, stated with the estimate: 15%; at least 1.4-fold (0.15 log units) between middle value and limit.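

In this assay, compound 3 gives > 100000 nM, which is a limit of the assay and not a number. For the compounds shown here, this gives the first measured look at what happens when 2-chlorophenyl becomes 2-fluorophenyl, a change on an aromatic carbon, ortho to a large group: the result is an at least 1.6-fold higher number from compound 2 to compound 3 (0.21 log units; that floor lies within the scatter). Since that step is only a floor, it points upward without giving a size, so the true gap may be small or much larger, and the reading offers no exact value to build on: the limit of > 100000 nM in this assay, at which 1 of the 3 values shown sits.

The compounds shown leave open how other groups at this same position would read, such as a methyl, a methoxy or an amine, and whether any of them would bring the reading back within the measurable range. They also leave open whether the same swap of chloro for fluoro would have a similar outcome on another core, and a single pair cannot establish a general rule for this change.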